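This account rests on a few compounds, and the source may have more. Where it says the series, first, only, none or still open, it means among the compounds named here.

Of the compounds shown here, three sharing one core have been measured in an ADME assay on liver for metabolic stability, with Liver microsome (Homo sapiens) as the target, read by LC-MS, using microsomes; on this read-out lower numbers stand for slow clearance and higher numbers for fast clearance. Among the compounds with values here, compound 1 `O=C(NCc1cc(Cl)ccc1-n1cnnn1)[C@@H]1CC=NN1C(=O)[C@H](O)c1ccccc1F` gives 16 mL.min-1.g-1, the only plain number among them. Compound 2 `CC(C)(C)[C@@H](O)C(=O)N1OCC[C@H]1C(=O)NCc1cc(Cl)ccc1-n1cnnn1` reports < 12 mL.min-1.g-1, which is a limit of the assay rather than a number. Compound 3 `O=C(NCc1cc(Cl)ccc1-n1cnnn1)[C@@H]1[C@@H]2C[C@@H]2CN1C(=O)[C@H](O)c1ccccc1F` likewise reports < 12 mL.min-1.g-1, again a limit. Within the data shown here, compound 1 therefore stands as the single number, set against (the limit of < 12 mL.min-1.g-1 in this assay, at which 2 of the 3 values shown sit). Compound 4 `O=C(NCc1cc(Cl)ccc1-n1cnnn1)[C@@H]1CC=NN1C(=O)[C@H](O)C1CCCCC1` is not yet measured; it differs from compound 1 by cyclohexyl in place of 2-fluorophenyl on a saturated chain carbon bound to a carbonyl carbon and an oxygen on a saturated carbon. Among the measured compounds shown here, no measured pair shows this change, so its effect is open. For compound 4 a modest rise in this assay is expected, a 1.6-fold higher number from compound 1 to compound 4 (0.19 log units; within the scatter), possibly no more than the usual scatter. The estimate for compound 4 is 25 mL.min-1.g-1, with a range from 12 mL.min-1.g-1 to 60 mL.min-1.g-1.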

Compound 4, intrinsic clearance in microsomes: 63 mL.min-1.g-1
The estimate for compound 4 lay 2.5-fold (0.40 log units) below the measured number; the whole stated range lies below it.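

In this assay, this position now shows a clear response to a change: cyclohexyl in place of 2-fluorophenyl gives a 3.9-fold higher number from compound 1 to compound 4 (0.60 log units; beyond the scatter), a step beyond the usual scatter. The ring at this place is therefore not a neutral choice for this read-out, although a single pair cannot separate the loss of the fluorine from the loss of the aromatic ring. As far as these compounds go, whether plain phenyl, without fluorine, would sit nearer compound 1 or compound 4 remains open. Further comparison within this set is also restricted: the limit of < 12 mL.min-1.g-1 in this assay, at which 2 of the 4 values shown sit.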